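The compounds below may be only part of what the source reports. "The series", "measured", "known", "first", "only" and "open" are said of these compounds alone.

Of the compounds shown here, two from one series have been measured in a functional assay on the whole organism (muscle tissue) with Rattus norvegicus as the target; a lower number here means a smaller maximal response, a higher number a larger maximal response. Compound 1 `CCNC(=O)C1=CC(C)(C)Oc2ccc([N+](=O)[O-])cc21` gives 80.5% in this assay. Compound 2 `CC1(C)C=C(C(=O)NC2CC2)c2cc([N+](=O)[O-])ccc2O1`, with cyclopropyl in place of ethyl on the amide-type nitrogen, gives 78% in this assay. For the measured compounds named here, that step, a number 2.5 percentage points lower from compound 1 to compound 2 (within the scatter), shows two numbers that sit within the scatter of each other, so compound 2 and compound 1 cannot be told apart on this read-out; compound 1 is the only neighbour compound 2 has.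

Compound 3 `CC1(C)C=C(C(=O)NCCO)c2cc([N+](=O)[O-])ccc2O1` is not yet measured. The change from compound 2 is 2-hydroxyethyl in place of cyclopropyl on an amide-type nitrogen. Going by the values given here, the only step that bears on it is the earlier change at the same amide-type nitrogen, which was within the scatter. A swap of one small group for another at that position is therefore expected to leave the maximal response largely unchanged, with no step beyond the scatter in this assay: the expected step is a number 1 percentage points lower from compound 2 to compound 3 (within the scatter). Compound 3 is estimated to give 77% in this assay, in a range from 62% to 90%.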

Compound 3, intrinsic activity: the largest response reached, in percent of the reference agonist's: 71.8%
The estimate for compound 3 lay 5.2 percentage points above the measured number; the measured number falls inside the stated range.
By their numbers in this assay, from the lowest: compounds 3, 2 and 1 (each within the scatter of the next).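

With 2-hydroxyethyl on the amide-type nitrogen, a group with no ring and with a hydrogen-bond donor and acceptor that cyclopropyl lacks, this assay still gives no step beyond the scatter: the change shows a number 6.2 percentage points lower from compound 2 to compound 3 (within the scatter). Compound 1 and compound 3 differ only by hydroxy in place of hydrogen on the saturated chain, and that pair shows a number 8.7 percentage points lower from compound 1 to compound 3 (within the scatter), so a hydroxy group on this chain, like the earlier swap of ethyl for cyclopropyl, cannot be told apart on this read-out. No information is available to explain these numbers.

On these data alone, whether the maximal response would hold with an amine or a carboxylic acid at the end of the chain, or with a longer chain on this nitrogen, remains open. As far as these compounds go, the effect of changes elsewhere on the shared core also remains open.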